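Replacing chloro with hydrogen on compound 2

The source may hold more compounds than are shown below. What is called first, only, known or untested is meant among the compounds shown, and "the series" means these compounds.

Of the compounds shown here, two so far have numbers in a functional assay on SK-MEL-2 cells (Homo sapiens) for cytotoxicity; on this read-out lower numbers stand for stronger inhibition and higher numbers for weaker inhibition. Compound 1 `Cc1ccc2c(O)nc(-c3ccccc3)cc2c1` gives 1580 nM. Compound 2 `CN1CCN(c2nc(-c3ccc(Cl)cc3)cc3c(N(C)C)cccc23)CC1` gives 4300 nM, the higher of the two numbers and thus the weaker inhibition, with a gap to compound 1 beyond the usual scatter. Compound 3 `CN1CCN(c2nc(-c3ccccc3)cc3c(N(C)C)cccc23)CC1` has not yet been measured in this assay. It differs from compound 2 in one place, hydrogen in place of chloro on an aromatic carbon, turning 4-chlorophenyl into phenyl. Among the compounds with values here, no measured pair shows this change, so the data give no direct guide to its size. No step beyond the scatter is expected in either direction, and the expectation is anchored on compound 2 at 4300 nM. The estimated step is a 1.1-fold lower number from compound 2 to compound 3 (0.03 log units; within the scatter). For compound 3 the estimated value is 4000 nM, with an expected range of 1500 nM to 10000 nM.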

Compound 3, half-maximal inhibitory concentration: 7080 nM
Compound 3: middle estimate off by 1.8-fold (0.25 log units), on the low side; measured number inside the range.
By their numbers in this assay, from the lowest: compound 1; then compounds 2 and 3 (each within the scatter of the next).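

In this assay, within the data shown here, going from 4-chlorophenyl to phenyl gives a 1.6-fold higher number from compound 2 to compound 3 (0.22 log units; within the scatter) as the only direct reading of this change. On this pair, the chloro on the six-membered aromatic ring can give way to hydrogen without a step beyond the scatter, so the two compounds cannot be told apart on this read-out. No measurement at hand bears on the reason for this result.

As far as these compounds go, whether a fluoro, a methoxy, an amine or a carboxylic acid at this place would also stay within the scatter of compound 2 and compound 3 remains open. Also open, from the compounds shown here alone, is whether the same change would read alike with something other than the methylpiperazine and dimethylamino groups on the shared core, and compound 1 differs in too many places to help.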